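The compounds below may be only part of what the source reports. "The series", "measured", "known", "first", "only" and "open" are said of these compounds alone.

In a physicochemical assay for lipophilicity, measured as octanol-water partition (on this read-out higher numbers stand for higher lipophilicity and lower numbers for lower lipophilicity), compound 1 `Cc1ccc(/C=N/c2ccccc2C(=O)NNc2ccnc3cc(Cl)ccc23)cc1` gives 5.31 and compound 2 `COc1ccc(/C=N/c2ccccc2C(=O)NNc2ccnc3cc(Cl)ccc23)cc1` gives 5 while compound 3 `CN(C)c1ccc(/C=N/c2ccccc2C(=O)NNc2ccnc3cc(Cl)ccc23)cc1` gives 5.03 and so lies within the scatter of both. Compound 4 `O=C(NNc1ccnc2cc(Cl)ccc12)c1ccccc1/N=C/c1ccncc1` is still unmeasured and differs from compound 3 by pyridin-4-yl in place of 4-(dimethylamino)phenyl on a carbon with a double bond to nitrogen with pyridin-4-yl in place of 4-(dimethylamino)phenyl on a carbon with a double bond to nitrogen. The measured steps exchange only a group on an aromatic carbon: a number 0.31 log units lower from compound 1 to compound 2 (beyond the scatter) and a number 0.28 log units lower from compound 1 to compound 3 (within the scatter) and a number 0.03 log units higher from compound 2 to compound 3 (within the scatter) (none replaces a whole ring) so they guide only weakly. The ring that enters holds a hetero atom and the group is smaller, so from compound 3 at 5.03 a clearly lower number is expected in this assay than any of those steps gives. The expected step is a number 1.13 log units lower from compound 3 to compound 4 (beyond the scatter) as a rough estimate. For compound 4 the estimate is 3.9 with values between 3.3 and 4.5 as its expected range.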

Compound 4, partition coefficient: 3.86
The estimate for compound 4 lay 0.04 log units above the measured number; the measured number falls inside the stated range.
By their numbers in this assay, from the lowest: compound 4; then compounds 2, 3 and 1 (each within the scatter of the next, the first and the last beyond it).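

In this assay the ring on the carbon with a double bond to nitrogen matters far more than the group exchanged on the aromatic carbon, with pyridin-4-yl giving a number 1.17 log units lower from compound 3 to compound 4 (beyond the scatter) and a number 1.14 log units lower from compound 2 to compound 4 (beyond the scatter) and a number 1.45 log units lower from compound 1 to compound 4 (beyond the scatter) in turn. The step stays large whichever of the three carbon-only rings leaves.

The compounds shown cannot separate the hetero atom of the entering ring from its smaller size, which a plain phenyl ring at this place could do. Nothing available here explains the drop.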